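The compounds below may be only part of what the source reports. "The series", "measured", "known", "first", "only" and "open" are said of these compounds alone.

Working notes on the series. The shared core of compound 1 `Cc1cc(NC(=O)Cn2nnc(-c3ccccc3)n2)n(C2CCCCC2)n1` carries a cyclohexyl on an aromatic nitrogen; in an assay on HEK293 cells for activation of Kir3.1/Kir3.2 (Homo sapiens), read by thallium flux (on this read-out lower numbers stand for smaller maximal responses and higher numbers for larger maximal responses), compound 1 gives 92%. Compound 2 `Cc1cc(NC(=S)Cn2nnc(-c3ccccc3)n2)n(C2CCCCC2)n1` reaches 80% in this assay. Compound 3 `Cc1cc(NC(=O)Cn2nnc(-c3ccccc3)n2)n(C2CCC(F)(F)CC2)n1` gives 68% in this assay and thus stands lowest of the three measured numbers, with compound 2 nearest above it and compound 1 furthest. Among the measured compounds shown here, the one single-change step known so far, a number 24 percentage points lower from compound 1 to compound 3 (beyond the scatter), shows that swapping the group on the aromatic nitrogen shifts the maximal response by a modest but clear amount.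

Compound 4 `Cc1cc(NC(=O)Cn2nnc(-c3ccccc3)n2)n(C(C)C)n1` is not yet measured. Relative to compound 3 it differs as follows: isopropyl in place of 4,4-difluorocyclohexyl on an aromatic nitrogen. For the measured compounds named here, the only bearing step is the one from compound 1 to compound 3, and it points in neither direction for a ring-free group of this kind, so no step beyond the scatter is firmly expected. The estimate for compound 4 is 75% in this assay, within a range of 52% to 95%, which would mean an expected step of a number 7 percentage points higher from compound 3 to compound 4 (within the scatter).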

Compound 4, largest response reached (Emax), in percent of the reference or control that the assay uses: 107%
For compound 4 the middle estimate is 32 percentage points below the measured one; the measured number lies above the stated range.
By their numbers in this assay, from the lowest: compound 3; then compound 2; then compound 1; then compound 4.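

On the aromatic nitrogen, a ring is not needed for a full response in this assay: isopropyl in place of 4,4-difluorocyclohexyl gives a number 39 percentage points higher from compound 3 to compound 4 (beyond the scatter), and isopropyl in place of cyclohexyl gives a number 15 percentage points higher from compound 1 to compound 4 (beyond the scatter). Among these three groups, the position therefore spans a wider range than the fluorine change alone had shown, with isopropyl above cyclohexyl and cyclohexyl above 4,4-difluorocyclohexyl, all by steps beyond the scatter. Nothing at hand explains why the ring-free group gives the larger response.

Still open, on these data alone, is whether a shorter group such as ethyl, a branched group such as tert-butyl or a smaller ring such as cyclobutyl would keep the response of compound 4. Also open, as far as these compounds go, is whether isopropyl would raise the response on the thiocarbonyl core of compound 2.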